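Sulfonamide hydrazone series: bromo-to-chloro exchange on the aryl ring

A few compounds are considered here, and "the series" means these few. Any claim that something is new, unique, unknown or untested is made for them only; others in the source may bear on it.

Measured compounds:
- compound 1 `C/C(=N/NC(=O)c1ccc(S(N)(=O)=O)cc1)c1ccc(Br)cc1` — 37600 nM
- compound 2 `C/C(=N/NC(=O)c1ccc(S(N)(=O)=O)cc1)c1ccc(Cl)cc1` — 62700 nM
- compound 3 `NS(=O)(=O)c1ccc(N/N=C(/CS(=O)(=O)c2ccccc2)c2ccc(Br)cc2)cc1` — 12900 nM

Of the compounds shown here, three have been measured in an ADME assay on MCF-10A cells (Homo sapiens) for antiproliferative activity, read by MTT assay; a lower number here means a stronger inhibitor, a higher number a weaker inhibitor. Compound 1 `C/C(=N/NC(=O)c1ccc(S(N)(=O)=O)cc1)c1ccc(Br)cc1` and compound 2 `C/C(=N/NC(=O)c1ccc(S(N)(=O)=O)cc1)c1ccc(Cl)cc1` share one core; compound 3 `NS(=O)(=O)c1ccc(N/N=C(/CS(=O)(=O)c2ccccc2)c2ccc(Br)cc2)cc1` is built on a second core, and the difference between the two cores is not broken down here. In this assay compound 1 gives 37600 nM and compound 2 gives 62700 nM; the change between them is chloro in place of bromo on an aromatic carbon, and the step is a 1.7-fold higher number from compound 1 to compound 2 (0.22 log units; within the scatter). Compound 3 gives 12900 nM in this assay, the lowest of the three numbers, and its distance to compound 1 and to compound 2 is beyond the scatter in both cases.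

Compound 4 `NS(=O)(=O)c1ccc(N/N=C(/CS(=O)(=O)c2ccccc2)c2ccc(Cl)cc2)cc1` has not been measured. It differs from compound 3 by chloro in place of bromo on an aromatic carbon, the same change that turns compound 1 into compound 2, made at the same kind of place on the same kind of ring. On the first core this change gave a 1.7-fold higher number from compound 1 to compound 2 (0.22 log units; within the scatter), a step within the scatter. Within the data shown here, with only one prior example, on a different core, the expectation for compound 4 in this assay rests on that single step: a small shift toward a higher number, a 1.6-fold higher number from compound 3 to compound 4 (0.19 log units; within the scatter), is expected. Compound 4 is therefore estimated at 20000 nM in this assay, with a likely range from 8000 nM to 50000 nM.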

Compound 4, half-maximal inhibitory concentration: 28600 nM
Beside the measured number, compound 4's estimate is 1.4-fold (0.16 log units) below it; low and high end bracket the measured number.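

In this assay, chloro in place of bromo on an aromatic carbon gives a 2.2-fold higher number from compound 3 to compound 4 (0.35 log units; beyond the scatter), a modest step on the core of compound 3. Set against the step on the core of compound 1, the size of the change cannot be told apart between the two cores, even though only the newer step lies beyond the scatter: the same change on two cores in this assay, a 1.7-fold higher number (0.22 log units; within the scatter) from compound 1 to compound 2 and a 2.2-fold higher number (0.35 log units; beyond the scatter) from compound 3 to compound 4, 1.3-fold (0.12 log units) apart, within the scatter of two such steps This supports treating the exchange as carrying over between these two cores in this assay, but it rests on just two matched pairs, with one exchange at one place, 4-bromophenyl to 4-chlorophenyl, and it neither gives a reason for the step nor establishes a rule for any further core.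

Open, from the compounds shown here alone, is whether a fluoro, a methyl, a methoxy or an amine at that same place would follow the bromo and chloro compounds on either core, or whether the numbers would move well away from theirs. Also open is what separates the two cores themselves, as the compounds shown on them differ in more than one place and no single change links one core to the other.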